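This account rests on a few compounds, and the source may have more. Where it says the series, first, only, none or still open, it means among the compounds named here.

Working notes on the series. Compound 1 `COc1ccccc1CNC1(CCC(C)(C)C)C(=O)C(C2=NS(=O)(=O)c3cc(NS(C)(=O)=O)ccc3N2)=C(O)c2ccccc21` and compound 2 `Cc1cccc(C)c1CN[C@]1(CCC(C)(C)C)C(=O)C(C2=NS(=O)(=O)c3cc(NS(C)(=O)=O)ccc3N2)=C(O)c2ccccc21` share one core and have both been run in an in vivo ADME assay on the whole organism (strain Sprague-Dawley) for pharmacokinetics, with Rattus norvegicus as the target, at a dose of 5 mg/kg by the oral route; on this read-out higher numbers stand for higher oral bioavailability and lower numbers for lower oral bioavailability. In this assay, within the data shown here, compound 1 gives 48%, while compound 2 gives 55.9%; the two numbers sit inside the scatter of each other, so no ranking of the pair can be drawn from them, and compound 1 simply occupies one end of a narrow band of two readings. Compound 3 `Cc1cccc(CNC2(CCC(C)(C)C)C(=O)C(C3=NS(=O)(=O)c4cc(NS(C)(=O)=O)ccc4N3)=C(O)c3ccccc32)n1` has not been measured in this assay. It differs from compound 1 in one place: 6-methylpyridin-2-yl in place of 2-methoxyphenyl on a saturated chain carbon bound to an amine nitrogen. No measured pair of the series shows this kind of change, so there is no shown step to lean on; the expectation is a step of no more than the usual scatter, if anything slightly downward, as a number 4 percentage points lower from compound 1 to compound 3 (within the scatter). Compound 3 is therefore estimated at 44%, with a likely range from 24% to 66%.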

Compound 3, oral bioavailability: 33.8%
Compound 3: the middle estimate sits 10.2 percentage points above what was measured; low and high end bracket the measured number.
By their numbers in this assay, from the lowest: compound 3; then compounds 1 and 2 (each within the scatter of the next).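

Among these compounds, compound 1 and compound 3 give the first one-place step: in this assay, 6-methylpyridin-2-yl in place of 2-methoxyphenyl on a saturated chain carbon bound to an amine nitrogen gives a number 14.2 percentage points lower from compound 1 to compound 3 (beyond the scatter). This position therefore does not tolerate every aryl group equally on this read-out, even though the two groups have the same hydrogen-bond donor and acceptor counts and neither carries a net charge. No measured property is available to explain the step.

The step changes the ring atoms and the substituent together, and the compounds shown do not separate these two changes. A 3-methylphenyl or a 6-methoxypyridin-2-yl group at this place would give each change on its own.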